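The source may report more compounds than this note shows. Statements on the series, on what has been measured and on what is new or still open speak of the compounds shown alone.

In a functional assay on MCF7 cells (Homo sapiens) for inhibition, read by sulforhodamine B assay, with a stated time of 72 h (a lower number here means a stronger inhibitor of growth, a higher number a weaker inhibitor of growth), compound 1 `CCOC(=O)/C=C/c1ccncc1-c1ccc2[nH]ccc2c1` gives > 10000 nM, which is a limit of the assay and not a number. Compound 2 `O=C(CCc1ccncc1-c1ccc2ccccc2c1)N1CCOCC1` gives > 10000 nM, which is likewise a limit. Going by the values given here, compound 3 `CCOC(=O)/C=C/c1ccncc1-c1ccc2c(ccn2C)c1` gives 8670 nM, the only true number in the set. The rest of the set sits at the limit of > 10000 nM in this assay, at which 2 of the 3 values shown sit.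

The next compound, compound 4 `CNC(=O)/C=C/c1ccncc1-c1ccc2c(ccn2C)c1`, carries methylamino in place of ethoxy on a carbonyl carbon. Among the compounds with values here, only one measured step exists, an at least 1.1-fold lower number from compound 1 to compound 3 (0.06 log units; that floor lies within the scatter). It stays within the scatter and leaves the carbonyl carbon untouched, so it bears on the new change only indirectly. Within the data shown here, no measured compound shows what this exchange does, which leaves no firm ground for a direction. The expectation therefore starts from compound 3 at 8670 nM, with no step beyond the scatter in this assay. The expected move is a 1.0-fold higher number from compound 3 to compound 4 (0.02 log units; within the scatter). The estimate for compound 4 is 9000 nM, with a range from 3000 nM to 27000 nM.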

Compound 4, concentration for 50% growth inhibition: 7120 nM
For compound 4 the middle estimate is 1.3-fold (0.10 log units) above the measured one; measured number inside the range.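

In this assay, going by these compounds alone, the exchange of ethoxy for methylamino on the carbonyl carbon gives the first readable step at this position: a 1.2-fold lower number from compound 3 to compound 4 (0.09 log units; within the scatter). Ethoxycarbonyl and methylcarbamoyl therefore cannot be told apart here, even though the exchange also brings in a hydrogen-bond donor. The pair adds a second true number to a set otherwise held at a limit of the assay, which is not a number, so comparisons remain few: the limit of > 10000 nM in this assay, at which 2 of the 4 values shown sit.

From the compounds shown here alone, whether a carboxylic acid, a dimethylamino group or a longer chain on the amide nitrogen at this carbonyl carbon would separate from compound 3 and compound 4 stays open. Also open, going by these compounds, is what hydrogen in place of methyl on the aromatic nitrogen would do when methylcarbamoyl is present.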